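Swapping isopropyl for trifluoromethyl on the aryl group

The compounds below may be only part of what the source reports. "The series", "measured", "known", "first", "only" and "open" are said of these compounds alone.

Of the compounds shown here, two have been measured in an assay on cells (Endothelial cell) for binding affinity to Endothelin-1 receptor (Sus scrofa); on this read-out higher numbers stand for weaker inhibition and lower numbers for stronger inhibition. Compound 1 `COc1cccc(Oc2c(NS(=O)(=O)c3ccc(C(C)(C)C)cc3)ncnc2OCCOc2nccs2)c1` gives 12 nM in this assay. Compound 2 `CSc1cnc(OCCOc2ncnc(NS(=O)(=O)c3ccc(C(C)(C)C)cc3)c2-c2ccc(C(C)C)cc2)nc1` gives 1.2 nM in this assay, the lower of the two numbers, and its gap to compound 1 lies beyond the usual scatter. Compound 3 `CSc1cnc(OCCOc2ncnc(NS(=O)(=O)c3ccc(C(C)(C)C)cc3)c2-c2ccc(C(F)(F)F)cc2)nc1` differs from compound 2 in one place: trifluoromethyl in place of isopropyl on an aromatic carbon. Among the measured compounds shown here, no measured pair shows this exact change, so the size of the step is uncertain. A modest shift toward weaker inhibition is expected, a 2.5-fold higher number from compound 2 to compound 3 (0.40 log units; beyond the scatter). Compound 3 is accordingly estimated at 3 nM, with a likely range from 0.8 nM to 12 nM.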

Compound 3, half-maximal inhibitory concentration: 0.0017 nM
For compound 3 the middle estimate is 1800-fold (3.25 log units) above the measured one; measured number below the stated range.
By their numbers in this assay, from the lowest: compound 3; then compound 2; then compound 1.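

Trifluoromethyl in place of isopropyl on this aromatic carbon gives a 710-fold lower number from compound 2 to compound 3 (2.85 log units; beyond the scatter) in this assay, a large move toward stronger inhibition. This shows that one small group at this place, far from being a minor detail, can change the read-out enormously. No available measurement gives a reason for a step of this size. On these data alone, whether a chlorine atom or a nitrile at the same place would give a similarly low number stays open. So does whether the same swap would have such an effect with other groups elsewhere on the shared core.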